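A Bromophenyl Swap Tested on a Second Hydrazone Core

The source may hold more compounds than are shown below. What is called first, only, known or untested is meant among the compounds shown, and "the series" means these compounds.

Compound 1 `COc1ccccc1-c1csc(N/N=C/c2ccc(F)c(F)c2)n1` and compound 2 `Fc1ccc(/C=N/Nc2nc(-c3cccc(Br)c3)cs2)cc1F` share a core and differ in one place: 3-bromophenyl in place of 2-methoxyphenyl on an aromatic carbon. In a functional assay on A549 cells (Homo sapiens) for inhibition, read by MTT assay, with a stated time of 48 h (on this read-out higher numbers stand for weaker inhibition and lower numbers for stronger inhibition), compound 1 gives 61300 nM, and compound 2 gives 16200 nM. That is a 3.8-fold lower number from compound 1 to compound 2 (0.58 log units; beyond the scatter).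

Compound 3 `COc1ccccc1-c1csc(N/N=C/c2cc(OC)c(OC)c(Br)c2Br)n1` carries the same 2-methoxyphenyl on a different core; how the two cores differ is not broken down here. In this assay compound 3 gives 85100 nM. Its value and that of compound 1 lie within the scatter of each other, while compound 2 stands beyond the scatter from both.

Compound 4 `COc1cc(/C=N/Nc2nc(-c3cccc(Br)c3)cs2)c(Br)c(Br)c1OC` has not yet been measured. It differs from compound 3 by 3-bromophenyl in place of 2-methoxyphenyl on an aromatic carbon, the same change as that from compound 1 to compound 2. If the change acts alike on the core of compound 3, compound 4 is expected to give 22000 nM in this assay, with a likely range from 8000 nM to 60000 nM. Among the measured compounds shown here, that expectation means a 3.9-fold lower number from compound 3 to compound 4 (0.59 log units; beyond the scatter), set beside the one measured step because a 3.8-fold lower number from compound 1 to compound 2 (0.58 log units; beyond the scatter) is the only measurement of this change. Since it rests on a single pair, the outcome for compound 4 could diverge.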

Compound 4, half-maximal inhibitory concentration: 37000 nM
The estimate for compound 4 lay 1.7-fold (0.23 log units) below the measured number, and the stated range covers the measured number.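

In this assay 3-bromophenyl in place of 2-methoxyphenyl on the core of compound 3 gave a 2.3-fold lower number from compound 3 to compound 4 (0.36 log units; beyond the scatter) as the measured step. Set beside the step on the core of compound 1, it runs in the same direction, and the two do not differ beyond what the scatter allows: the same change on two cores in this assay, a 3.8-fold lower number (0.58 log units; beyond the scatter) from compound 1 to compound 2 and a 2.3-fold lower number (0.36 log units; beyond the scatter) from compound 3 to compound 4, 1.6-fold (0.22 log units) apart, within the scatter of two such steps. In this series the change therefore carried from one core to the other in direction and, within the scatter, in size, but two pairs on two cores show no more than that and do not tell why the number falls or how the change would act on a further core.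

The compounds shown leave open whether another group at this place, such as a phenyl ring bearing an amine or a carboxylic acid, would shift the number as 3-bromophenyl does. They also leave open whether the same change would hold in any other assay.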